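Methyl in Place of Benzoyloxy: From Compound 3 to Compound 4

A few compounds are considered here, and "the series" means these few. Any claim that something is new, unique, unknown or untested is made for them only; others in the source may bear on it.

Compound 1 `COc1ccc(C(=O)/C(=C/C2CCCCC2)CC(C)OC(C)=O)cc1`: 33400 nM
Compound 2 `C=C(C(=O)c1ccc(OC)cc1)C(OC(=O)c1ccccc1)c1ccccc1F`: 14300 nM
Compound 3 `C=C(C/C(=C\c1ccc(OC(=O)c2ccccc2)cc1)C(=O)c1ccc(OC)cc1)C(=O)c1ccc(OC)cc1`: 6700 nM

All three compounds were tested in a functional assay on NB-4 cells (Homo sapiens) for inhibition, read by XTT assay, with a stated time of 48 h; on this read-out higher numbers stand for weaker inhibition and lower numbers for stronger inhibition. Compound 3 gives the lowest number of the three, 6700 nM. Compound 2 gives 14300 nM, and compound 1 gives 33400 nM. Both gaps to compound 3 lie beyond the scatter, so compound 3 is the strongest inhibitor among the measured compounds. The three structures differ in several places at once, so none of these gaps can be tied to a single change.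

Compound 4 `C=C(C/C(=C\c1ccc(C)cc1)C(=O)c1ccc(OC)cc1)C(=O)c1ccc(OC)cc1` is not yet measured. It differs from compound 3 in one place: methyl in place of benzoyloxy on an aromatic carbon, para to a large group. Going by the values given here, no measured pair in this set shows this change, so its size has not been observed here. A large group leaves and a single carbon enters. Compound 4 is expected to give a somewhat higher number than compound 3, a step of a 1.6-fold higher number from compound 3 to compound 4 (0.22 log units; within the scatter) in this assay, only modestly beyond the scatter if at all. Compound 4 is estimated at 11000 nM, with a range from 4500 nM to 27000 nM.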

Compound 4, half-maximal inhibitory concentration: 11400 nM
Compound 4: the middle estimate sits 1.0-fold (0.02 log units) below what was measured; measured number inside the range.
By their numbers in this assay, from the lowest: compounds 3, 4 and 2 (each within the scatter of the next, the first and the last beyond it); then compound 1.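

Going by these compounds alone, this is the first comparison in the set that isolates a single change: in this assay, methyl in place of benzoyloxy on an aromatic carbon, para to a large group, gives a 1.7-fold higher number from compound 3 to compound 4 (0.23 log units; within the scatter). Thus the whole benzoyloxy group, with its aromatic ring and two hydrogen-bond acceptors, can give way to a single carbon at this position without a step that clears the scatter. No measurement given here accounts for this result.

The compounds shown leave open whether a hydroxyl, an amine or a carboxylic acid at this position would stay within the same range. From the compounds shown here alone, whether this exchange would give a step of similar size on another core also remains open, as it is seen in this one pair only.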